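The source may hold more compounds than are shown below. What is called first, only, known or untested is meant among the compounds shown, and "the series" means these compounds.

Compound 2 `O=C(c1ccc(F)c(F)c1)N1CC(c2nc(-c3cccc(F)c3)no2)C1` gives 3200 nM in an assay on HEK293 cells for positive allosteric modulation of metabotropic glutamate receptor 5 (Homo sapiens), read by FLIPR (a lower number here means that less compound is needed, a higher number that more compound is needed for the effect), the higher of the two numbers obtained so far, while compound 1 `CC1CCCCC1C(=O)N1CC(c2nc(-c3cccc(F)c3)no2)C1` gives 540 nM in this assay. Going by the values given here, the only measured step is a 5.9-fold higher number from compound 1 to compound 2 (0.77 log units; beyond the scatter). Compound 3 `Cc1ccc(C(=O)N2CC(c3nc(-c4cccc(F)c4)no3)C2)cc1` differs from compound 2 by 4-methylphenyl in place of 3,4-difluorophenyl on a carbonyl carbon. This exchanges one six-membered aromatic ring for another on the carbonyl carbon, whereas the measured step replaced 2-methylcyclohexyl by an aromatic ring, so it bears on the question only loosely. With no aryl-for-aryl comparison in hand, no shift beyond the scatter is expected, a 1.3-fold lower number from compound 2 to compound 3 (0.11 log units; within the scatter). Compound 3 is estimated at 2500 nM, within 800 nM to 8000 nM.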

Compound 3, half-maximal effective concentration: 6800 nM
Compound 3: the middle estimate sits 2.7-fold (0.43 log units) below what was measured, within the range that was stated.
By their numbers in this assay, from the lowest: compound 1; then compound 2; then compound 3.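

On the carbonyl carbon, exchanging one aryl group for another is not neutral in this assay: 4-methylphenyl in place of 3,4-difluorophenyl gives a 2.1-fold higher number from compound 2 to compound 3 (0.33 log units; beyond the scatter) and so moves the number beyond the scatter. Replacing 2-methylcyclohexyl with 4-methylphenyl gives a 13-fold higher number from compound 1 to compound 3 (1.10 log units; beyond the scatter) as a larger step, leaving compound 1 below both aryl amides, compound 2 and compound 3. No available evidence accounts for either step.

Still open, from the compounds shown here alone, is whether plain cyclohexyl would keep the lower number without the methyl. Unsubstituted phenyl would help separate the contributions of the methyl and the two fluorines.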